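Series notes: aryl substituent on the imine nitrogen

This account rests on a few compounds, and the source may have more. Where it says the series, first, only, none or still open, it means among the compounds named here.

Compound 3 `CC1CCC(/C=N/c2ccc(O)cc2)=C2NC=C(C(=O)O)C(=O)N21` gives 1.2 umol/kg in a functional assay on the whole organism with Rattus norvegicus as the target (on this read-out lower numbers stand for an effect already at smaller amounts and higher numbers for an effect only at larger amounts of compound), the lowest number of the three measured. Compound 2 `CC1CCC(/C=N/c2ccccc2F)=C2NC=C(C(=O)O)C(=O)N21` gives 14.5 umol/kg, and compound 1 `CC1CC(/C=N/c2ccccc2C(=O)O)=C2NC=C(C(=O)O)C(=O)N2C1` gives 48.1 umol/kg. Compound 4 `Cc1ccc(/N=C/C2=C3NC=C(C(=O)O)C(=O)N3C(C)CC2)cc1` is the unmeasured member; it differs from compound 3 by methyl in place of hydroxy on an aromatic carbon, on an aromatic carbon of a six-membered aromatic ring of carbon only. Among the compounds with values here, the one step that bears on it, a 12-fold lower number from compound 2 to compound 3 (1.08 log units; beyond the scatter), changed the group on the same ring and was large, so the aryl substituent matters here. Within the data shown here, with hydroxy gone from compound 4, a step back toward higher numbers is expected, a 5.0-fold higher number from compound 3 to compound 4 (0.70 log units; beyond the scatter), though no measured pair isolates this exact change. Compound 4 is therefore estimated at 6 umol/kg, with a range from 1.5 umol/kg to 25 umol/kg.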

Compound 4, dose for 50% inhibition: 3.6 umol/kg
The estimate for compound 4 lay 1.7-fold (0.22 log units) above the measured number, and the stated range covers the measured number.
By their numbers in this assay, from the lowest: compound 3; then compound 4; then compound 2; then compound 1.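

In this assay, methyl in place of hydroxy on an aromatic carbon, para to a large group, gives a 3.0-fold higher number from compound 3 to compound 4 (0.48 log units; beyond the scatter), a modest step beyond the scatter. The 4-methylphenyl group lacks the hydrogen-bond donor of hydroxy yet still gives a 4.0-fold lower number from compound 2 to compound 4 (0.61 log units; beyond the scatter), so at this place a low number does not depend on hydroxy alone. No evidence is available that accounts for either step.

As far as these compounds go, it remains open how an amine or a methoxy group on this same aromatic carbon would read. The step from 2-fluorophenyl to 4-methylphenyl also leaves the effects of group and place unseparated.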